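This account rests on a few compounds, and the source may have more. Where it says the series, first, only, none or still open, it means among the compounds named here.

Compound 3 `C=CCOc1cc(OC)c(C(=O)/C=C/Cc2ccccc2)c(OCC=C)c1` is the starting point of this account. In a toxicity assay on cells (Macrophage, Mus musculus, strain BALB/c) for cytotoxicity, read by MTT assay (on this read-out higher numbers stand for weaker inhibition and lower numbers for stronger inhibition), compound 3 gives 14800 nM. Compound 1 `COc1cc(O)cc(O)c1C(=O)/C=C/c1ccc(Cl)cc1` gives 19000 nM in this assay, a value that sits within the scatter of that of compound 3, so the two cannot be told apart. Compound 2 `COCc1cc(COC)c(C(=O)/C=C/c2ccc(OC)cc2)c(OC)c1` reaches only a limit of this assay, > 250000 nM, with no number behind it. Compound 4 `C=CCOc1cc(OC)c(C(=O)/C=C/c2ccccc2Br)c(OCC=C)c1` has not yet been measured in this assay; it differs from compound 3 in one place: 2-bromophenyl in place of benzyl on a double-bonded chain carbon bound to a double-bonded chain carbon. Among the compounds with values here, no measured pair shows this change, so its effect is unknown. The step of a 1.2-fold lower number from compound 3 to compound 4 (0.09 log units; within the scatter) is expected to stay within the scatter. Compound 4 is therefore estimated at 12000 nM, between 4000 nM and 40000 nM.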

Compound 4, half-maximal inhibitory concentration: 5400 nM
Estimate against measurement, compound 4: 2.2-fold (0.35 log units) above, and the stated range covers the measured number.
By their numbers in this assay, from the lowest: compound 4; then compounds 3 and 1 (each within the scatter of the next). At a limit, above all of these: compound 2.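

In this assay, within the data shown here, putting 2-bromophenyl in place of benzyl gives a 2.7-fold lower number from compound 3 to compound 4 (0.44 log units; beyond the scatter), the first measured pair at this position. It shows that this place on a double-bonded chain carbon bound to a double-bonded chain carbon responds to a change of group, here towards stronger inhibition in this cytotoxicity read-out. Nothing measured here bears on the reason for this step. The compounds shown leave open how much of the step belongs to the bromine and how much to the change of chain from 3-phenylprop-1-en-1-yl to ethenyl. From the compounds shown here alone, how a plain phenyl, an amine or a carboxylic acid would read at this place also stays open.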